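A cyclohexyl amide in place of the trifluoromethylphenyl group

A few compounds are considered here, and "the series" means these few. Any claim that something is new, unique, unknown or untested is made for them only; others in the source may bear on it.

Compound 1 `O=C(Nc1cc(-c2ccccc2)nn1-c1ccccc1)c1cccc(C(F)(F)F)c1` in an assay on HEK293 cells for displacement of a labelled ligand from metabotropic glutamate receptor 5 (Rattus norvegicus); on this read-out lower numbers stand for stronger inhibition and higher numbers for weaker inhibition: 1650 nM
Compound 2 `N#Cc1ccc(C(=O)/N=c2\cc(-c3ccccc3)n(C(=O)c3ccc(C#N)cc3)n2-c2ccccc2)cc1` in this assay: 5230 nM

Of the two measured compounds, compound 1 has the lower number; compound 2 sits a clearly larger step away, beyond the usual scatter. Compound 3 `O=C(Nc1cc(-c2ccccc2)nn1-c1ccccc1)C1CCCCC1` has not yet been measured. It differs from compound 1 in one place: cyclohexyl in place of 3-(trifluoromethyl)phenyl on a carbonyl carbon. Within the data shown here, no measured pair shows the effect of such a change, so the expectation rests on compound 1 alone and on the change itself. Exchanging the aromatic ring for a non-aromatic ring on this carbonyl carbon is expected to weaken binding in this assay, and a step of moderate size towards higher numbers is estimated: a 3.6-fold higher number from compound 1 to compound 3 (0.56 log units; beyond the scatter). Compound 3 is therefore expected to give about 6000 nM, within a range from 1500 nM to 25000 nM.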

Compound 3, inhibition constant: 10100 nM
Compound 3: middle estimate off by 1.7-fold (0.23 log units), on the low side; the range from low to high includes it.
By their numbers in this assay, from the lowest: compound 1; then compounds 2 and 3 (each within the scatter of the next).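

Among these compounds, the exchange of 3-(trifluoromethyl)phenyl for cyclohexyl on a carbonyl carbon gives the first step in this assay between compounds that differ in one place, a 6.1-fold higher number from compound 1 to compound 3 (0.79 log units; beyond the scatter). This shows that the position is sensitive to this change, with the step pointing to weaker inhibition, and that a non-aromatic ring of carbon only keeps measurable binding while losing ground to the aromatic group of compound 1. No measurement shown here accounts for the size or direction of this step.

Going by these compounds, the aromatic ring and the trifluoromethyl group leave together in this change, so their separate contributions remain open. On these data alone, how an unsubstituted phenyl, or an open chain such as hexyl, would stand on this carbonyl carbon also remains open.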